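Swapping chloro for methoxy on the biaryl tail

The source may report more compounds than this note shows. Statements on the series, on what has been measured and on what is new or still open speak of the compounds shown alone.

Of the compounds shown here, three sharing one core have been measured in a physicochemical assay for lipophilicity, read by HPLC, at pH 7.5; a higher number here means a more lipophilic compound, a lower number a more polar compound. Compound 1 `CC[C@@H](Nc1c(C#N)c(-c2ccc(-c3ncccc3C)cc2)nc2cnccc12)C(N)=O` gives 2. Compound 2 `CCOc1ccccc1-c1ccc(-c2nc3cnccc3c(N[C@H](CC)C(N)=O)c2C#N)cc1` gives 3, and compound 3 `CC[C@@H](Nc1c(C#N)c(-c2ccc(-c3cccc(Cl)c3)cc2)nc2cnccc12)C(N)=O` gives 3.1. Among these three numbers compound 3 stands highest, though the step of a number 0.10 log units higher from compound 2 to compound 3 (within the scatter) lies within the scatter, while a number 1.10 log units higher from compound 1 to compound 3 (beyond the scatter) is a clear rise beyond it.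

Compound 4 `CC[C@@H](Nc1c(C#N)c(-c2ccc(-c3cccc(OC)c3)cc2)nc2cnccc12)C(N)=O` is the next member of the series. Its difference from compound 3 is methoxy in place of chloro on an aromatic carbon. Among the measured compounds shown here, the one measured step that bears on this exchange is a number 0.10 log units higher from compound 2 to compound 3 (within the scatter), where an alkoxy group on the outer ring gave way to a chloro with no change beyond the scatter. For the measured compounds named here, that step points toward little movement here, but no measured pair exchanges chloro for methoxy on the same carbon, so the account leans on it only loosely and expects a small downward step a number 0.50 log units lower from compound 3 to compound 4 (beyond the scatter). On that basis compound 4 is estimated at 2.6, expected to fall between 2.2 and 3.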

Compound 4, distribution coefficient: 2.7
Compound 4: the middle estimate sits 0.10 log units below what was measured; the measured number falls inside the stated range.
By their numbers in this assay, from the lowest: compound 1; then compounds 4, 2 and 3 (each within the scatter of the next, the first and the last beyond it).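

In this assay, among the compounds shown here, the exchange of chloro for methoxy on an aromatic carbon, meta to a large group, gives a number 0.40 log units lower from compound 3 to compound 4 (beyond the scatter) and so provides the first direct reading of a change at this carbon, one that lies beyond the scatter. Compound 4 also places the 3-methoxyphenyl tail against the two other tails, with a number 0.30 log units lower from compound 2 to compound 4 (within the scatter) and a number 0.70 log units higher from compound 1 to compound 4 (beyond the scatter) as the steps, and compound 1 remains the lowest of the four. Nothing available here accounts for the size of the chloro to methoxy step.

The compounds shown leave open what an amine, a hydroxy group or a carboxylic acid would give on this same carbon. They also leave open whether methoxy in place of chloro gives a similar step on another carbon of the ring.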